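A few compounds are considered here, and "the series" means these few. Any claim that something is new, unique, unknown or untested is made for them only; others in the source may bear on it.

Three compounds share one core and differ only in the amine attached to it. In an assay on isolated protein for displacement of a labelled ligand from corticotropin-releasing factor receptor 1 (Homo sapiens) (a lower number here means a stronger inhibitor, a higher number a weaker inhibitor), compound 1 `CCCN(CC1CC1)c1nc(C)nc2c(-c3ccc(Cl)cc3Cl)c(C)nn12` gives 0.7 nM and compound 2 `CCCN(CCC)c1nc(C)nc2c(-c3ccc(Cl)cc3Cl)c(C)nn12` gives 0.6 nM; the step of a 1.2-fold lower number from compound 1 to compound 2 (0.07 log units; within the scatter) stays within the scatter. Compound 3 `CCC(COC)Nc1nc(C)nc2c(-c3ccc(Cl)cc3Cl)c(C)nn12` gives 1.9 nM, the highest number of the three, through the steps of a 2.7-fold higher number from compound 1 to compound 3 (0.43 log units; beyond the scatter) and a 3.2-fold higher number from compound 2 to compound 3 (0.50 log units; beyond the scatter). Compound 4 `CCCC(CC)Nc1nc(C)nc2c(-c3ccc(Cl)cc3Cl)c(C)nn12` is made from compound 3 by the change (ethyl in place of methoxy on a saturated chain carbon, two bonds along the chain from a nitrogen on an aromatic ring), which removes the only ether from the amine side chain and brings it closer to the all-carbon amines of compounds 1 and 2. Both bearing steps were modest, so for compound 4 a modest step of a 1.7-fold lower number from compound 3 to compound 4 (0.24 log units; within the scatter) towards a lower number is expected in this assay, giving an estimate of 1.1 nM with a range from 0.45 nM to 2.8 nM.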

Compound 4, inhibition constant: 1.2 nM
Estimate against measurement, compound 4: 1.1-fold (0.04 log units) below; the range from low to high includes it.
By their numbers in this assay, from the lowest: compounds 2, 1, 4 and 3 (each within the scatter of the next, the first and the last beyond it).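

The step of a 1.6-fold lower number from compound 3 to compound 4 (0.20 log units; within the scatter) shows that in this assay ethyl can stand in for methoxy at this place on the chain with no change beyond the scatter. The (1-ethylbutyl)amino group also stays close to both earlier amines, through the steps of a 2.0-fold higher number from compound 2 to compound 4 (0.30 log units; within the scatter) and a 1.7-fold higher number from compound 1 to compound 4 (0.23 log units; within the scatter), unlike the (1-(methoxymethyl)propyl)amino group of compound 3. Nothing here explains why these numbers fall as they do. Open, from the compounds shown here alone, is how a hydroxyl group or a carboxylic acid at this place on the chain would compare.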